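Pyridinyl Ethyl in Place of the Phenyl Tertiary Carbon

The source may hold more compounds than are shown below. What is called first, only, known or untested is meant among the compounds shown, and "the series" means these compounds.

Compound 1 `Cn1ncc2c(=O)n(-c3ccccc3)c(SC(C)(C)c3ccccc3)nc21` was tested in an assay on isolated protein for inhibition of Retinaldehyde dehydrogenase 3 (Homo sapiens) (a higher number here means a weaker inhibitor, a lower number a stronger inhibitor), where compound 1 gives 1390 nM. Its only companion, compound 2 `CC(Sc1nc2c(cnn2C)c(=O)n1-c1ccc(CO)cc1)c1ccccc1`, gives 1000 nM in this assay, a value the usual scatter does not separate from that of compound 1. Compound 3 `CC(Sc1nc2c(cnn2C)c(=O)n1-c1ccccc1)c1ccccn1` carries 1-(pyridin-2-yl)ethyl in place of 1-methyl-1-phenylethyl on a sulfur. Within the data shown here, no measured pair shows such a change, so its effect is uncertain; with compound 2 at 1000 nM as the closest anchor, the expected step is a 1.5-fold lower number from compound 1 to compound 3 (0.19 log units; within the scatter), small and within the scatter. Compound 3 is therefore expected to give 900 nM in this assay, between 300 nM and 3000 nM.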

Compound 3, half-maximal inhibitory concentration: 89 nM
Compound 3: the middle estimate sits 10-fold (1.00 log units) above what was measured; measured number below the stated range.
By their numbers in this assay, from the lowest: compound 3; then compounds 2 and 1 (each within the scatter of the next).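

In this assay, the group on the sulfur proves able to move the number a long way: 1-(pyridin-2-yl)ethyl in place of 1-methyl-1-phenylethyl gives a 16-fold lower number from compound 1 to compound 3 (1.19 log units; beyond the scatter), a clear gain that the two earlier compounds gave no sign of. Nothing available explains this gain. The change brings a ring nitrogen and removes a methyl in one step, and the compounds shown cannot tell which of the two carries the effect. As far as these compounds go, how a 1-(pyridin-3-yl)ethyl group on the same sulfur would compare also remains open.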